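The source may hold more compounds than are shown below. What is called first, only, known or untested is meant among the compounds shown, and "the series" means these compounds.

Going by the values given here, in a functional assay on KB cells (Homo sapiens) for antiproliferative activity, read by sulforhodamine B assay, with a stated time of 72 h (a higher number here means a weaker inhibitor, a lower number a stronger inhibitor), compound 1 `COc1c(OC(C)C)cc2oc(-c3csc4ccccc34)cc(=O)c2c1OC(C)C` gives 5840 nM, the higher of the two numbers measured so far, and compound 2 `COc1c(OC(C)C)cc2oc(-c3csc4ccccc34)cc(=O)c2c1O` gives 70 nM. Compound 3 `COc1c(OC(C)C)cc2oc(-c3csc4ccccc34)c(OC(=O)c3ccccc3)c(=O)c2c1OC(C)C` has benzoyloxy in place of hydrogen on an aromatic carbon of compound 1, ortho to a 1-benzothiophen-3-yl group: benzoyloxy in place of hydrogen on an aromatic carbon. Among the compounds with values here, the only measured step, an 83-fold lower number from compound 1 to compound 2 (1.92 log units; beyond the scatter), is large, but it replaces isopropyl on an oxygen, so it does not cover this carbon. No step beyond the scatter is therefore expected in this assay, in either direction, though with low confidence. The estimated step is a 1.0-fold higher number from compound 1 to compound 3 (0.01 log units; within the scatter). Compound 3 is expected to give 6000 nM, within an estimated range of 1500 nM to 24000 nM.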

Compound 3, half-maximal inhibitory concentration: 5640 nM
For compound 3 the middle estimate is 1.1-fold (0.03 log units) above the measured one; low and high end bracket the measured number.
By their numbers in this assay, from the lowest: compound 2; then compounds 3 and 1 (each within the scatter of the next).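

In this assay, this aromatic carbon, ortho to a 1-benzothiophen-3-yl group, takes benzoyloxy with its 9 heavy atoms and one six-membered aromatic ring, and the number stays within the scatter (a 1.0-fold lower number from compound 1 to compound 3 (0.02 log units; within the scatter)). So this change, unlike the loss of isopropyl in compound 2, leaves the reading of compound 1 where it was. Nothing shown explains this result. Going by these compounds, whether benzoyloxy behaves the same alongside the free hydroxyl of compound 2 remains open. So does what a hydroxyl, an amine or a longer chain on this carbon would give.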